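A few compounds are considered here, and "the series" means these few. Any claim that something is new, unique, unknown or untested is made for them only; others in the source may bear on it.

Measured so far in an ADME assay on the whole organism (Rattus norvegicus, strain Wistar Han) for pharmacokinetics, at a dose of 0.05 mg/kg by the intravenous route; on this read-out higher numbers stand for fast clearance and lower numbers for slow clearance:

compound 1 `COC(=O)N1c2ccc(C3(NC(=O)c4ccc(F)cc4)CC3)cc2[C@@H]2CC[C@@H]21`: 29 mL/min/kg
compound 2 `O=C(Nc1ccc(Cl)cc1)C1(c2ccc3c(n2)CCN3c2ccccn2)CCC1`: 53 mL/min/kg
compound 3 `O=C(OC1CC1)N1CCc2nc(C3(C(=O)Nc4ccc(F)cc4)CCC3)ccc21`: 61 mL/min/kg

Compound 3 gives the highest of the three numbers in this assay. Its nearest neighbour is compound 2, whose number lies within the usual scatter of repeated measurements, so the two cannot be told apart on this read-out. Compound 1 stands further off, at a lower number, and that gap does lie beyond the scatter. No pair among these three differs in only one place, so no single structural step can be read from the measured set.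

The next compound, compound 4 `O=C(C1CC1)N1CCc2nc(C3(C(=O)Nc4ccc(F)cc4)CCC3)ccc21`, is to be measured in this assay. It differs from compound 3 in one place: cyclopropyl in place of cyclopropyloxy on a carbonyl carbon. Cut one bond further out, the change reads cyclopropyloxycarbonyl to cyclopropylcarbonyl, on a carbonyl carbon whose other neighbour is an amide-type nitrogen in a ring.

With no measured step of this kind in the series, the expectation for compound 4 rests on compound 3 alone, at 61 mL/min/kg, and the step expected from compound 3 to compound 4, a 1.1-fold lower number from compound 3 to compound 4 (0.04 log units; within the scatter), is estimated to stay within the scatter, with no clear direction. Compound 4 is therefore estimated at 55 mL/min/kg, with a range from 28 mL/min/kg to 105 mL/min/kg.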

Compound 4, clearance: 60 mL/min/kg
The estimate for compound 4 lay 1.1-fold (0.04 log units) below the measured number; measured number inside the range.
By their numbers in this assay, from the lowest: compounds 1, 2, 4 and 3 (each within the scatter of the next, the first and the last beyond it).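

In this assay, the series now has its first single-place step: cyclopropyl in place of cyclopropyloxy on a carbonyl carbon gives a 1.0-fold lower number from compound 3 to compound 4 (0.01 log units; within the scatter), which is within the scatter. At this place, on a carbonyl carbon whose other neighbour is an amide-type nitrogen in a ring, the two groups therefore cannot be told apart on this read-out, even though one carries an oxygen that the other lacks. No measurement at hand accounts for this result.

This single step does not show whether other groups on this carbonyl carbon would read the same, for example a dimethylamino group or a longer alkyl chain in place of the cyclopropyl. Nor does it show whether the same exchange would give a step of similar size on a different core, such as that of compound 1, so the result holds only for the pair compound 3 and compound 4.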